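Removing a methyl from compound 3

The source may report more compounds than this note shows. Statements on the series, on what has been measured and on what is new or still open speak of the compounds shown alone.

Values in a functional assay on HCT-116 cells (Homo sapiens) for inhibition, read by MTT assay, with a stated time of 48 h; a higher number here means a weaker inhibitor, a lower number a stronger inhibitor
compound 1 `COc1cc(-c2cc(-c3cccc(O)c3)nc(-c3ccccc3)n2)cc(OC)c1OC` gives 20400 nM
compound 2 `COc1cc(-c2cc(-c3ccccc3)nc(-c3ccccc3)n2)cc(OC)c1OC` gives 9950 nM
compound 3 `COc1ccc(-c2cc(-c3cc(OC)c(OC)c(OC)c3)nc(-c3ccccc3)n2)cc1` gives 4780 nM

Of these three, compound 3 has the lowest number, and its gaps to both others lie beyond the scatter. Compound 4 `COc1cc(-c2cc(-c3ccc(O)cc3)nc(-c3ccccc3)n2)cc(OC)c1OC` carries 4-hydroxyphenyl instead of 4-methoxyphenyl, with hydrogen in place of methyl on an oxygen on an aromatic ring. Among the compounds with values here, two measured steps bear on this. Adding the methoxy gave a 2.1-fold lower number from compound 2 to compound 3 (0.32 log units; beyond the scatter), and removing the hydroxy gave a 2.1-fold lower number from compound 1 to compound 2 (0.31 log units; beyond the scatter). Both are modest and point towards a higher number with hydroxy than with methoxy, so a modest rise is expected in this assay. The estimated change is a 2.5-fold higher number from compound 3 to compound 4 (0.40 log units; beyond the scatter). For compound 4 the estimated value is 12000 nM, within a range of 4500 nM to 30000 nM.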

Compound 4, half-maximal inhibitory concentration: 11900 nM
Estimate against measurement, compound 4: 1.0-fold (0.00 log units) above; measured number inside the range.
By their numbers in this assay, from the lowest: compound 3; then compounds 2, 4 and 1 (each within the scatter of the next, the first and the last beyond it).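

In this assay, the methyl on the oxygen proves to matter, since replacing it with hydrogen gives a 2.5-fold higher number from compound 3 to compound 4 (0.40 log units; beyond the scatter). The free hydroxy itself stays within the scatter against plain hydrogen (a 1.2-fold higher number from compound 2 to compound 4 (0.08 log units; within the scatter)), and moving it on the ring, with 4-hydroxyphenyl in place of 3-hydroxyphenyl, also stays within the scatter (a 1.7-fold lower number from compound 1 to compound 4 (0.23 log units; within the scatter)), so the methoxy stands out among these groups. No measurement here explains this difference.

As far as these compounds go, whether a longer chain on that oxygen, such as ethoxy, or an amine in place of the methoxy, would lower the number further remains open.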